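Replacing 2-fluorophenyl with 2-chlorophenyl in the series

The source may report more compounds than this note shows. Statements on the series, on what has been measured and on what is new or still open speak of the compounds shown alone.

In a functional assay on SGC-7901 cells (Homo sapiens) for inhibition, read by MTT assay, with a stated time of 24 h (a higher number here means a weaker inhibitor, a lower number a stronger inhibitor), compound 1 `CC1(C)[C@H]2CC[C@]1(C)N(Cc1cn(-c3ccccc3Br)nn1)C(=O)C2` gives 500 nM and compound 2 `CC1(C)[C@H]2CC[C@]1(C)N(Cc1cn(-c3ccc(C#N)cc3)nn1)C(=O)C2` gives 500 nM on the same read-out. Compound 3 `CC1(C)[C@H]2CC[C@]1(C)N(Cc1cn(-c3ccccc3F)nn1)C(=O)C2` at 300 nM stands within the scatter of both. Compound 4 `CC1(C)[C@H]2CC[C@]1(C)N(Cc1cn(-c3ccccc3Cl)nn1)C(=O)C2` carries chloro in place of fluoro on an aromatic carbon, ortho to a large group (chloro in place of fluoro on an aromatic carbon). The nearest measured change is fluoro in place of bromo (a 1.7-fold lower number from compound 1 to compound 3 (0.22 log units; within the scatter)), which stays within the scatter. The other two steps (a 1.7-fold lower number from compound 2 to compound 3 (0.22 log units; within the scatter)) and (no change at the digits printed from compound 1 to compound 2 (within the scatter)) also stay within it. No step beyond the scatter is therefore expected in this assay for this exchange. The expected step is small (a 1.3-fold higher number from compound 3 to compound 4 (0.12 log units; within the scatter)). Compound 4 is estimated at 400 nM with an expected range from 200 nM to 800 nM on this read-out.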

Compound 4, half-maximal inhibitory concentration: 220 nM
Compound 4: the middle estimate sits 1.8-fold (0.26 log units) above what was measured; the range from low to high includes it.
By their numbers in this assay, from the lowest: compounds 4, 3, 1 and 2 (each within the scatter of the next, the first and the last beyond it).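

In this assay, the change from 2-fluorophenyl to 2-chlorophenyl stays within the scatter (a 1.4-fold lower number from compound 3 to compound 4 (0.13 log units; within the scatter)), so fluoro and chloro are not separated at this position. Chloro gives the first steps in the series beyond the scatter, both modest: in place of bromo (a 2.3-fold lower number from compound 1 to compound 4 (0.36 log units; beyond the scatter)), and as 2-chlorophenyl in place of 4-cyanophenyl (a 2.3-fold lower number from compound 2 to compound 4 (0.36 log units; beyond the scatter)). No measurement on hand bears on the reason for these steps.

Open, going by these compounds, is how a methoxy group or an amine at this position would compare with chloro. Also open, on these data alone, is whether the chloro result extends to other cell lines.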